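Swapping a ring substituent on the amide nitrogen: a small step

The source may hold more compounds than are shown below. What is called first, only, known or untested is meant among the compounds shown, and "the series" means these compounds.

Measured so far:
Compound 1, `CC(C)N1C(=O)COc2ccc(-c3cccc(NS(=O)(=O)c4ccc(F)cc4)c3)cc21`: 29400 nM
Compound 2, `O=C1COc2ccc(-c3cccc(NS(=O)(=O)c4ccc(F)cc4)c3)cc2N1c1ccc(Cl)cc1`: 31600 nM
Compound 3, `COc1ncc(-c2ccc3c(c2)N(c2ccc(Cl)cc2)C(=O)CO3)cc1NS(=O)(=O)c1ccc(F)cc1`: 8350 nM

All three were tested in a functional assay on A549 cells (Homo sapiens) for antiproliferative activity, read by MTT assay, with a stated time of 72 h; a higher number here means a weaker inhibitor, a lower number a stronger inhibitor. Compound 1 and compound 2 share one core and differ in a single place, (isopropyl in place of 4-chlorophenyl on an amide-type nitrogen in a ring). That change gave a 1.1-fold lower number from compound 2 to compound 1 (0.03 log units; within the scatter), so the two compounds cannot be told apart on this read-out. Compound 3 sits on a different core; how the two cores differ is not broken down here. In this assay compound 3 gives 8350 nM, the lowest of the three numbers, beyond the scatter from both of the others.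

Compound 4, `COc1ncc(-c2ccc3c(c2)N(C(C)C)C(=O)CO3)cc1NS(=O)(=O)c1ccc(F)cc1`, has not yet been measured. Going by the values given here, it differs from compound 3 by isopropyl in place of 4-chlorophenyl on an amide-type nitrogen in a ring, the same change as the one from compound 2 to compound 1, made at the same kind of place. Because that earlier step was a 1.1-fold lower number from compound 2 to compound 1 (0.03 log units; within the scatter), the step from compound 3 to compound 4 is expected to be small too, about a 1.1-fold lower number from compound 3 to compound 4 (0.03 log units; within the scatter). Compound 4 is therefore estimated at 7800 nM, with a likely range from 3500 nM to 17000 nM.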

Compound 4, half-maximal inhibitory concentration: 4920 nM
For compound 4 the middle estimate is 1.6-fold (0.20 log units) above the measured one; measured number inside the range.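

In this assay, putting isopropyl in place of 4-chlorophenyl on the amide-type nitrogen gave a 1.7-fold lower number from compound 3 to compound 4 (0.23 log units; within the scatter), so the step stays small on this second core as well. Set beside the earlier step, the change carries over from one core to the other without a difference that can be told from scatter: the same change on two cores in this assay, a 1.1-fold lower number (0.03 log units; within the scatter) from compound 2 to compound 1 and a 1.7-fold lower number (0.23 log units; within the scatter) from compound 3 to compound 4, 1.6-fold (0.20 log units) apart, within the scatter of two such steps. This shows agreement between two pairs of compounds on a single read-out, but it does not show that the change would stay small on a further core, nor does it explain why the two groups give such similar results.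

From the compounds shown here alone, it remains open whether a longer chain, an amine or a carboxylic acid on that same nitrogen would leave the number as little changed as isopropyl and 4-chlorophenyl do. Also open is how the swap would read on a core other than the two shown here.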